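Benzyl for Aryl on the Triazole Nitrogen

A few compounds are considered here, and "the series" means these few. Any claim that something is new, unique, unknown or untested is made for them only; others in the source may bear on it.

Compound 1 `COc1ccc(-n2cc(CSC(=S)N3CCN(C(=O)OC(C)(C)C)CC3)nn2)cc1` — > 128000 nM
Compound 2 `CC(C)(C)OC(=O)N1CCN(C(=S)SCc2cn(Cc3cc(=O)oc4cc(O)ccc34)nn2)CC1` — 36800 nM

In a functional assay on PC-3 cells (Homo sapiens) for inhibition, read by MTT assay, with a stated time of 72 h (on this read-out higher numbers stand for weaker inhibition and lower numbers for stronger inhibition), compound 1 gives > 128000 nM, which is a limit of the assay and not a number. Compound 1 therefore stands at the edge of the measured range (the limit of > 128000 nM in this assay, at which 1 of the 2 values shown sits). Compound 2, which carries a different group on the same ring nitrogen, gives 36800 nM in this assay. Compound 3 `Cc1ccc(Cn2cc(CSC(=S)N3CCN(C(=O)OC(C)(C)C)CC3)nn2)cc1` is not yet measured; it differs from compound 1 by 4-methylbenzyl in place of 4-methoxyphenyl on an aromatic nitrogen. Among the measured compounds shown here, no measured pair shows exactly this change, so the size of the step is uncertain; the one benzyl-type compound at hand, compound 2, sits inside the measured range, and a move beyond the scatter toward stronger inhibition seems somewhat more likely than none. Compound 3 is estimated at 60000 nM, with a range from 15000 nM to 150000 nM. This estimate implies an expected step of an at least 2.1-fold lower number from compound 1 to compound 3 (0.32 log units; beyond the scatter).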

Compound 3, half-maximal inhibitory concentration: 17300 nM
Beside the measured number, compound 3's estimate is 3.5-fold (0.54 log units) above it; the range from low to high includes it.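

Among the compounds shown here, replacing 4-methoxyphenyl with 4-methylbenzyl on the aromatic nitrogen gives the first step at this position that can be read from a pair differing in one place: in this assay there is an at least 7.3-fold lower number from compound 1 to compound 3 (0.86 log units; beyond the scatter). This single change, with the rest of the core of compound 1 kept, is enough to bring a compound from the edge of the measured range to a value inside it. The size of the step can only be read as a minimum, since the value of compound 1 is a limit and not a number: the limit of > 128000 nM in this assay, at which 1 of the 3 values shown sits.

The compounds shown leave open whether the step belongs to the benzyl form or to methyl in place of methoxy, which 4-methoxybenzyl or 4-methylphenyl on the same nitrogen could separate. They also leave open how a benzyl bearing an amine or a carboxylic acid would read here.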